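The compounds below may be only part of what the source reports. "The series", "measured", "known", "first", "only" and "open" are said of these compounds alone.

Compound 1 `COc1ccc(/C=N/NC(=O)Nc2ccc(Oc3ccnc(-c4nncn4CCN(C)C)c3)c(F)c2)c(OC)c1` — in a functional assay on A549 cells (Homo sapiens) for cytotoxicity, read by MTT assay, with a stated time of 72 h (a higher number here means a weaker inhibitor, a lower number a stronger inhibitor), compound 1 gives 2820 nM.
Compound 2 `CN(C)CCn1cnnc1-c1cc(Oc2ccc(NC(=O)N/N=C/c3ccc(F)cc3)cc2F)ccn1` — in this assay compound 2 gives 1790 nM.
Compound 3 `CN(C)CCn1cnnc1-c1cc(Oc2ccc(NC(=O)N/N=C/c3c(O)ccc4ccccc34)cc2F)ccn1` — in this assay compound 3 gives 880 nM.

Compound 1 has the highest of the three numbers in this assay. Its nearest neighbour is compound 2, a 1.6-fold lower number from compound 1 to compound 2 (0.20 log units; within the scatter); furthest is compound 3, a 3.2-fold lower number from compound 1 to compound 3 (0.51 log units; beyond the scatter). Between the other two, a 2.0-fold lower number from compound 2 to compound 3 (0.31 log units; beyond the scatter).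

Compound 4 `CN(C)CCn1cnnc1-c1cc(Oc2ccc(NC(=O)N/N=C/c3ccc(O)cc3)cc2F)ccn1` has not yet been measured. It differs from compound 1 in one place: 4-hydroxyphenyl in place of 2,4-dimethoxyphenyl on a carbon with a double bond to nitrogen. The step from compound 1 to compound 2 bears most directly on this change, since it also exchanges the 2,4-dimethoxyphenyl for a single six-membered aromatic ring of carbon only, and that step stayed within the scatter. The larger step from compound 1 to compound 3 involves the 2-hydroxynaphthalen-1-yl, which compound 4 does not carry. Compound 4 is therefore expected to land close to compound 2, with a 1.6-fold lower number from compound 1 to compound 4 (0.19 log units; within the scatter) expected to stay within the scatter. The estimate for compound 4 in this assay is 1800 nM, with a range from 700 nM to 4500 nM.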

Compound 4, half-maximal inhibitory concentration: 3560 nM
Beside the measured number, compound 4's estimate is 2.0-fold (0.30 log units) below it; measured number inside the range.
By their numbers in this assay, from the lowest: compound 3; then compounds 2, 1 and 4 (each within the scatter of the next).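

At this carbon with a double bond to nitrogen, 4-hydroxyphenyl in place of 2,4-dimethoxyphenyl gives a 1.3-fold higher number from compound 1 to compound 4 (0.10 log units; within the scatter), so a single hydrogen-bond donor on the ring does not separate the two compounds in this assay. Hydroxy in place of fluoro on an aromatic carbon gives a 2.0-fold higher number from compound 2 to compound 4 (0.30 log units; within the scatter), which leaves compound 1, compound 2 and compound 4 unresolved from one another. A hydroxy group on a single six-membered ring therefore does not reproduce what the 2-hydroxynaphthalen-1-yl of compound 3 shows, with a 4.0-fold higher number from compound 3 to compound 4 (0.61 log units; beyond the scatter).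

No measurement at hand accounts for these numbers. Going by these compounds, it remains open whether a plain naphthalen-1-yl or a 2-hydroxyphenyl would come closer to compound 3, which would show whether the second ring or the hydroxy group placed there matters more.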